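The source may hold more compounds than are shown below. What is called first, only, known or untested is meant among the compounds shown, and "the series" means these compounds.

Of the compounds shown here, three have so far been measured in a functional assay on A549 cells (Homo sapiens) for antiproliferative activity, with a stated time of 72 h, tested at 50 ug/mL; a higher number here means a stronger effect of the compound at the concentration tested, a lower number a weaker effect. Compound 1 `O=c1[nH]nc2n(c1=O)CCN2c1ccccc1` gives 17%. Compound 2 `N=c1c(=O)[nH]nc2n1CCN2c1ccccc1` gives 38%; the difference between the two cores of compound 1 and compound 2 is not broken down here. Compound 3 `O=c1[nH]nc2n(c1=O)CCN2c1cccc(Cl)c1` gives 0%. The change from compound 1 to compound 3 is chloro in place of hydrogen on an aromatic carbon, and it made a step of a number 17 percentage points lower from compound 1 to compound 3 (beyond the scatter). Compound 4 `N=c1c(=O)[nH]nc2n1CCN2c1ccc(Cl)cc1` has not yet been measured in this assay; it differs from compound 2 by chloro in place of hydrogen on an aromatic carbon. This is the same kind of change as that from compound 1 to compound 3, though not the same: there the chloro sits meta to a large group, here para to a large group. Expected here is a number 18 percentage points lower from compound 2 to compound 4 (beyond the scatter), resting on the earlier step of a number 17 percentage points lower from compound 1 to compound 3 (beyond the scatter) made by the same kind of change. Compound 4 is therefore estimated to give 20% in this assay.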

Compound 4, a percentage reported as inhibition, at one concentration (the size of the read-out at that concentration, not a potency): 27%
For compound 4 the middle estimate is 7 percentage points below the measured one; low and high end bracket the measured number.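

In this assay, chloro in place of hydrogen on the aromatic ring gives a lower number on both cores, and the new step, a number 11 percentage points lower from compound 2 to compound 4 (beyond the scatter), agrees with the earlier one: the same change on two cores in this assay, a number 17 percentage points lower (beyond the scatter) from compound 1 to compound 3 and a number 11 percentage points lower (beyond the scatter) from compound 2 to compound 4, 6 percentage points apart, within the scatter of two such steps. On these two pairs, then, the change carries over from one core to the other in direction and, as far as the scatter can tell, in size. This does not show that it would carry over to other cores, and because the chloro in compound 4 sits para to a large group while that in compound 3 sits elsewhere on the ring, the two pairs cannot separate the core from the position.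

The compounds shown leave open what a chloro at the same position on both cores would do. They also leave open how a different group on the ring, such as a fluoro, a methoxy or an amine, would behave on either core.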